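Trading fluoro for trifluoromethyl in a cell toxicity test

The source may report more compounds than this note shows. Statements on the series, on what has been measured and on what is new or still open speak of the compounds shown alone.

In an ADME assay on MT4 cells (Homo sapiens) for cytotoxicity, read by MTT assay, with a stated time of 4 days (on this read-out higher numbers stand for lower toxicity in this test and lower numbers for higher toxicity in this test), compound 1 (`CC(=O)Nc1ccc2oc(-c3cccc(C(F)(F)F)c3)cc(=O)c2c1`) gives 10000 nM. Compound 2 (`CC(=O)Nc1ccc2oc(-c3cccc(F)c3)c(O)c(=O)c2c1`) gives 26500 nM, the higher of the two numbers, and the gap between them lies beyond the usual scatter. Compound 2 is therefore the less toxic of this pair. Compound 3 (`CC(=O)Nc1ccc2oc(-c3cccc(C(F)(F)F)c3)c(O)c(=O)c2c1`) has not been measured yet. It differs from compound 2 in one place, with trifluoromethyl in place of fluoro on an aromatic carbon. Going by the values given here, no measured pair shows this swap alone, so the evidence is thin. Compound 1 also carries trifluoromethyl, though it differs elsewhere too, and it gives 10000 nM. A small downward move in this assay is therefore expected, probably not beyond the scatter. The estimated change is a 1.7-fold lower number from compound 2 to compound 3 (0.22 log units; within the scatter). Compound 3 is expected to give 16000 nM, with an estimated range of 7000 nM to 35000 nM.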

Compound 3, half-maximal cytotoxic concentration: 5700 nM
Compound 3: middle estimate off by 2.8-fold (0.45 log units), on the high side, and the stated range ends above it.
By their numbers in this assay, from the lowest: compounds 3 and 1 (each within the scatter of the next); then compound 2.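

In this assay the swap of fluoro for trifluoromethyl on this aromatic carbon can now be read directly: the result is a 4.6-fold lower number from compound 2 to compound 3 (0.67 log units; beyond the scatter) and so points to higher toxicity in this test. With trifluoromethyl kept in place, hydroxy in place of hydrogen on an aromatic carbon gives a 1.8-fold lower number from compound 1 to compound 3 (0.24 log units; within the scatter) and so cannot be told apart from no change in this test. Nothing in the data explains why the swap of fluoro for trifluoromethyl has this effect.

The compounds shown leave open whether a methyl or a chloro group on the same carbon would read like fluoro or like trifluoromethyl. On these data alone, it also remains open whether the swap would give a similar step with an amine in place of the hydroxy group.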